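The compounds below may be only part of what the source reports. "The series", "measured", "known", "first", "only" and "open" are said of these compounds alone.

Measured compounds:
compound 1 `CCCN1CC[C@@]2(OC)OC(N)=C(C#N)[C@@H](c3ccc(Cl)cc3Cl)[C@@H]2C1` gives 35500 nM
compound 2 `CCCN1CC[C@@]2(OC)OC(N)=C(C#N)[C@@H](c3ccc(F)cc3)[C@@H]2C1` gives 29600 nM
compound 3 `CCCN1CC[C@@]2(OC)OC(N)=C(C#N)[C@@H](c3ccc(C)cc3)[C@@H]2C1` gives 21000 nM

All three share one core and differ only in the aromatic ring attached to a saturated ring carbon. In a functional assay on trachea (Cavia porcellus) (a lower number here means a stronger inhibitor, a higher number a weaker inhibitor), the three numbers sit close together: the step of a 1.7-fold lower number from compound 1 to compound 3 (0.23 log units; within the scatter) is the largest, and a 1.2-fold lower number from compound 1 to compound 2 (0.08 log units; within the scatter) and a 1.4-fold lower number from compound 2 to compound 3 (0.15 log units; within the scatter) are smaller still. For the measured compounds named here, compound 3 therefore has the lowest number of the three, but no measured step between these compounds reaches beyond the scatter, so none of them can be called stronger or weaker than another.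

Compound 4 `CCCN1CC[C@@]2(OC)OC(N)=C(C#N)[C@@H](c3ccc(OC)cc3)[C@@H]2C1` is not yet measured. It differs from compound 3 by methoxy in place of methyl on an aromatic carbon. Going by the values given here, no measured step changes this group, so the only guidance is that every exchange on the aromatic ring so far, such as a 1.4-fold lower number from compound 2 to compound 3 (0.15 log units; within the scatter), stayed within the scatter. The step of a 1.1-fold lower number from compound 3 to compound 4 (0.02 log units; within the scatter) is therefore expected to be small, with no clear direction. Compound 4 is estimated at 20000 nM, within a range from 8000 nM to 50000 nM, in this assay.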

Compound 4, half-maximal inhibitory concentration: 21300 nM
The estimate for compound 4 lay 1.1-fold (0.03 log units) below the measured number; the range from low to high includes it.
By their numbers in this assay, from the lowest: compounds 3, 4, 2 and 1 (each within the scatter of the next).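

In this assay, methoxy in place of methyl on the aromatic ring, para to a large group, gives a 1.0-fold higher number from compound 3 to compound 4 (0.01 log units; within the scatter) and so adds an oxygen and a hydrogen-bond acceptor without a readable effect on the number. The other two comparisons read the same way, with a 1.4-fold lower number from compound 2 to compound 4 (0.14 log units; within the scatter) and a 1.7-fold lower number from compound 1 to compound 4 (0.22 log units; within the scatter), so the four aromatic rings shown cannot be told apart at this position. No supporting measurement is available to explain why these numbers stay so close.

As far as these compounds go, whether an amine or a carboxylic acid on this aromatic ring would produce a step beyond the scatter remains open. Also open, from the compounds shown here alone, is whether a change away from this ring, such as a longer chain on the shared core, would do so.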